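Halogen swap on a sulfonamide versus an amide core

A few compounds are considered here, and "the series" means these few. Any claim that something is new, unique, unknown or untested is made for them only; others in the source may bear on it.

Measured compounds in an assay on HEK293 cells for positive allosteric modulation of metabotropic glutamate receptor 5 (Homo sapiens), read by FLIPR; a higher number here means that more compound is needed for the effect, a lower number that less compound is needed:
compound 1, `O=C(C1CCC(F)(F)CC1)N1CC(c2nc(-c3cccc(F)c3)no2)C1`: 520 nM
compound 2, `O=S(=O)(c1ccc(F)cc1)N1CC(c2nc(-c3cccc(Cl)c3)no2)C1`: > 10000 nM
compound 3, `O=C(C1CCC(F)(F)CC1)N1CC(c2nc(-c3cccc(Cl)c3)no2)C1`: 180 nM

Compound 1 and compound 3 share one core and differ by chloro in place of fluoro on an aromatic carbon. That change gave a 2.9-fold lower number from compound 1 to compound 3 (0.46 log units; beyond the scatter). Compound 2 carries a different core; the difference between the two cores is not broken down here. For compound 2 the result is a limit of this assay, not a number, as shown by the limit of > 10000 nM in this assay, at which 1 of the 3 values shown sits.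

Compound 4, `O=S(=O)(c1ccc(Cl)cc1)N1CC(c2nc(-c3cccc(Cl)c3)no2)C1`, has not yet been measured. It stands to compound 2 as compound 3 stands to compound 1, through (chloro in place of fluoro on an aromatic carbon); the place differs, para to a large group instead of meta to a large group, so it is the same kind of change, not the same. For the measured compounds named here, because compound 2 sits at the limit of > 10000 nM in this assay, at which 1 of the 3 values shown sits, no numerical step is known for the core of compound 4, and the earlier step from compound 1 to compound 3 belongs to another core. The step from compound 2 to compound 4 is expected to be a step that the limit leaves unreadable from compound 2 to compound 4. Compound 4 is estimated at 15000 nM, between 4000 nM and 50000 nM, most likely again a limit.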

Compound 4, half-maximal effective concentration: > 10000 nM
Compound 4 ended at the assay's limit (the forecaster's own chance of this, stated with the estimate: 70%); the middle value does not contradict the limit.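

No step can be read from compound 2 to compound 4, because both ended at a limit of the assay, not at a number: the limit of > 10000 nM in this assay, at which 2 of the 4 values shown sit.

On these data alone, whether going from 4-fluorophenyl to 4-chlorophenyl changes anything on this core remains open.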